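The source may report more compounds than this note shows. Statements on the series, on what has been measured and on what is new or still open speak of the compounds shown alone.

Compound 1 `O=C(Nc1ccc(F)cc1CN1C(=O)c2ccccc2C1=O)c1ccccn1`, measured in an assay on CHO cells for positive allosteric modulation of metabotropic glutamate receptor 5 (Homo sapiens), read by FLIPR; on this read-out higher numbers stand for an effect only at larger amounts of compound and lower numbers for an effect already at smaller amounts: 1500 nM
Compound 2 `O=C(Nc1ccc(Cl)cc1CN1C(=O)c2ccccc2C1=O)c1ccccc1`, measured in the same assay: > 100000 nM

For the measured compounds named here, both measured compounds share one core and differ from each other in two places at once, so no single step between them can be drawn; their two values show only that compound 1 gives a number while compound 2 does not. For compound 2 the result in this assay is a limit of the assay and not a number: it sits at the limit of > 100000 nM in this assay, at which 1 of the 2 values shown sits. Compound 2 therefore stands at the weak edge of what the assay can report.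

Compound 3 `O=C(Nc1ccc(Cl)cc1CN1C(=O)c2ccccc2C1=O)c1ncccn1` has not yet been measured. It differs from compound 2 in one place: pyrimidin-2-yl in place of phenyl on a carbonyl carbon. Going by the values given here, the only measured compound that gives a number, compound 1, carries a nitrogen-bearing six-membered ring on that carbonyl carbon and gives 1500 nM. On that basis compound 3 is expected to give a measurable value, estimated at 2500 nM with a range from 500 nM to 30000 nM. The step from compound 2 to compound 3 is expected to be an at least 40-fold lower number from compound 2 to compound 3 (1.60 log units; beyond the scatter), a gain beyond the scatter, though its true size cannot be fixed while compound 2 shows only a limit.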

Compound 3, half-maximal effective concentration: 2100 nM
Beside the measured number, compound 3's estimate is 1.2-fold (0.08 log units) above it; the measured number falls inside the stated range.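

With the rest of the molecule unchanged, pyrimidin-2-yl in place of phenyl on a carbonyl carbon gives, in this assay, an at least 47-fold lower number from compound 2 to compound 3 (1.67 log units; beyond the scatter), and this is the only change among the compounds shown that can be read on its own. The two groups have the same count of 6 heavy atoms and both are six-membered aromatic rings, so the difference lies in the ring atoms: carbon only in phenyl, 2 nitrogen in pyrimidin-2-yl, which also brings 2 hydrogen-bond acceptors. The true size of the step stays unknown, because compound 2 gives only a limit of the assay and not a number: the limit of > 100000 nM in this assay, at which 1 of the 3 values shown sits.

Compound 1 and compound 3 differ in two places, so the compounds shown cannot separate the share of the ring on the carbonyl carbon from that of the halogen on the other ring. Going by these compounds, it also stays open whether both ring nitrogens are needed for the gain, and what cyclohexyl in that place, or an amine on the pyrimidin-2-yl ring, would do to the value.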